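Replacing the oxadiazolone ring at the branching carbon

A few compounds are considered here, and "the series" means these few. Any claim that something is new, unique, unknown or untested is made for them only; others in the source may bear on it.

Compound 1: `CC(C)C(Nc1nccs1)c1ccc(-c2ccc3cccc(F)c3c2)[nH]c1=O` — in a functional assay on CHO cells for antagonist activity at prostaglandin E2 receptor EP3 subtype (Homo sapiens), read by cAMP accumulation (a lower number here means a stronger inhibitor, a higher number a weaker inhibitor), compound 1 gives 10 nM
Compound 2: `CC(C)C(c1noc(=O)[nH]1)c1ccc(-c2ccc3cccc(F)c3c2)[nH]c1=O` — in this assay compound 2 gives 41 nM

Compound 2 has the highest of the two numbers, compound 1 standing at a 4.1-fold higher number from compound 1 to compound 2 (0.61 log units; beyond the scatter). Compound 3, `CC(C)C(c1ccc(-c2ccc3cccc(F)c3c2)[nH]c1=O)N1CCNC1=O`, differs from compound 2 by a group of 6 heavy atoms (3 carbon, 2 nitrogen, 1 oxygen; one five-membered non-aromatic ring with 2 hetero atoms) in place of a group of 6 heavy atoms (2 carbon, 2 nitrogen, 2 oxygen; one five-membered aromatic ring with 3 hetero atoms), on a saturated chain carbon bound to an aromatic carbon and a saturated chain carbon. For the measured compounds named here, only the step from compound 1 to compound 2 bears on this position, and it was modest. A change of similar size, again toward a higher number, is expected, so that compound 3 is estimated at 70 nM (range 15 nM to 300 nM), a step of a 1.7-fold higher number from compound 2 to compound 3 (0.23 log units; within the scatter).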

Compound 3, half-maximal inhibitory concentration in the prostaglandin E2 receptor EP3 subtype assay: 28 nM
The estimate for compound 3 lay 2.5-fold (0.40 log units) above the measured number; measured number inside the range.
By their numbers in the prostaglandin E2 receptor EP3 subtype assay, from the lowest: compound 1; then compounds 3 and 2 (each within the scatter of the next).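

In the prostaglandin E2 receptor EP3 subtype assay compound 2 gives 41 nM and compound 3 gives 28 nM: a five-membered non-aromatic ring, 2-oxoimidazolidin-1-yl, takes the place of the five-membered aromatic ring with no change beyond the scatter, a 1.5-fold lower number from compound 2 to compound 3 (0.17 log units; within the scatter), so an aromatic ring is not required on this saturated chain carbon. The (1,3-thiazol-2-yl)amino group still keeps the lowest of the three numbers, with the prostaglandin E2 receptor EP3 subtype assay showing a 2.8-fold higher number from compound 1 to compound 3 (0.45 log units; beyond the scatter). In a physicochemical assay for solubility, in phosphate buffer, measured as kinetic solubility (on this read-out higher numbers stand for higher solubility and lower numbers for lower solubility), compound 2 gives 32500 nM and compound 3 gives 24900 nM. In the physicochemical assay the same exchange also stays within the scatter, a 1.3-fold lower number from compound 2 to compound 3 (0.12 log units; within the scatter).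

Nothing shown explains these numbers. From the compounds shown here alone, whether a carboxylic acid or an open-chain urea on this carbon would match the (1,3-thiazol-2-yl)amino group remains open.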